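Adding a Methyl to the Core of Compound 1

The source may report more compounds than this note shows. Statements on the series, on what has been measured and on what is new or still open speak of the compounds shown alone.

Compound 1 `CCS[C@@H]1[C@H](SCC)[C@@H](Cn2cc(-c3ccc(OC)cc3)nn2)O[C@H]1n1ccc(=O)[nH]c1=O` was tested in a functional assay on HeLa cells (Homo sapiens) for cytotoxicity, read by MTT assay, with a stated time of 72 h (a higher number here means that more compound is needed for the effect, a lower number that less compound is needed), where compound 1 gives 27700 nM. Of the two numbers recorded, this is the lower one; compound 2 `CCS[C@@H]1[C@H](SCC)[C@@H](Cn2cc(-c3ccccc3C(F)(F)F)nn2)O[C@H]1n1ccc(=O)[nH]c1=O` gives 32800 nM, and the change is a 1.2-fold higher number from compound 1 to compound 2 (0.07 log units; within the scatter). For compound 3 `CCS[C@@H]1[C@H](SCC)[C@@H](Cn2cc(COC(C)=O)nn2)O[C@H]1n1ccc(=O)[nH]c1=O` the assay reports only a limit, >= 100000 nM. Compound 4 `CCS[C@@H]1[C@H](SCC)[C@@H](Cn2cc(-c3ccc(OC)cc3)nn2)O[C@H]1n1cc(C)c(=O)[nH]c1=O` differs from compound 1 by methyl in place of hydrogen on an aromatic carbon. Among the measured compounds shown here, no measured step touches this part of the shared core: the steps of a 1.2-fold higher number from compound 1 to compound 2 (0.07 log units; within the scatter) and an at least 3.6-fold higher number from compound 1 to compound 3 (0.55 log units; beyond the scatter) both exchange a group elsewhere in the molecule. With nothing bearing on the change, no shift beyond the scatter is expected. Compound 4 is therefore estimated at 28000 nM, within the range 10000 nM to 80000 nM, which corresponds to a 1.0-fold higher number from compound 1 to compound 4 (0.00 log units; within the scatter).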

Compound 4, half-maximal effective concentration: 66000 nM
Compound 4: the middle estimate sits 2.4-fold (0.37 log units) below what was measured; low and high end bracket the measured number.
By their numbers in this assay, from the lowest: compounds 1, 2 and 4 (each within the scatter of the next, the first and the last beyond it). At a limit, above all of these: compound 3.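

This position on the shared core is not silent. In this assay, among the compounds shown here, methyl in place of hydrogen on an aromatic carbon of the six-membered ring with 2 nitrogen gives a 2.4-fold higher number from compound 1 to compound 4 (0.38 log units; beyond the scatter), so a single added carbon matters here, whereas the earlier steps exchanged a group elsewhere in the molecule. Nothing shown accounts for this step.

As far as these compounds go, whether fluorine, an ethyl chain or an amine at this position would move the number further stays open. So does whether methyl here gives a similar step alongside the 2-(trifluoromethyl)phenyl group of compound 2.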